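Trimming the diacid amide back to a free acid

This account rests on a few compounds, and the source may have more. Where it says the series, first, only, none or still open, it means among the compounds named here.

This account follows two measured compounds and one still awaiting measurement in a physicochemical assay for lipophilicity, using the shake flask method; on this read-out lower numbers stand for lower lipophilicity and higher numbers for higher lipophilicity. Compound 1, `C[C@H](Oc1ccnc(C2CC2)c1)c1c(Cl)ccc(F)c1Cl`, gives 4.3 in this assay. Going by the values given here, compound 2, `C[C@H](Oc1ccc2ncc(/C=C/C(=O)NC(CC(=O)O)CC(=O)O)c(C3CC3)c2c1)c1c(Cl)ccc(F)c1Cl`, is the much larger of the two and carries the side chain with the double-bonded carbons and the diacid amide; in this assay compound 2 gives 0.4, the lowest of the two numbers known here and well beyond the scatter away from compound 1.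

Compound 3, `C[C@H](Oc1ccc2ncc(/C=C/C(=O)O)c(C3CC3)c2c1)c1c(Cl)ccc(F)c1Cl`, differs from compound 2 in one place: hydroxy in place of (2-carboxy-1-(carboxymethyl)ethyl)amino on a carbonyl carbon. Among the compounds with values here, the difference is counted from the structures alone, and no measured pair in this set shows what such a change does in this assay.

Her expectation rests on the two known values. Because compound 1 gives 4.3 and compound 2 gives 0.4, and compound 3 sits between them in size and in what it carries, she expects an upward step from compound 2 to compound 3 of about a number 1.60 log units higher from compound 2 to compound 3 (beyond the scatter), beyond the scatter. For compound 3 she estimates 2, within a range from 1 to 3.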

Compound 3, distribution coefficient: 4.1
Estimate against measurement, compound 3: 2.10 log units below, and the stated range ends below it.
By their numbers in this assay, from the lowest: compound 2; then compounds 3 and 1 (each within the scatter of the next).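

The change at this carbonyl carbon now has a reading of its own: in this assay, hydroxy in place of (2-carboxy-1-(carboxymethyl)ethyl)amino gives a number 3.70 log units higher from compound 2 to compound 3 (beyond the scatter), a large step. Nothing else differs between the two structures, so the whole of this step belongs to one exchange, on a carbonyl carbon whose other neighbour is the double-bonded chain carbon, in which a group of 10 heavy atoms with 3 hydrogen-bond donors leaves and a single oxygen as hydroxy enters. No measurement in hand explains why the step is this large.

This one pair cannot show how the step divides among the parts of the group that leaves: a methylamino group on the same carbonyl carbon, or an amide chain ending in a single carboxylic acid, would be needed to separate the amide link from the two carboxy arms. It also leaves open whether the same exchange would give a step of similar size on a shorter chain, or with a saturated ethylene chain in place of the double-bonded carbons.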